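The source may report more compounds than this note shows. Statements on the series, on what has been measured and on what is new or still open speak of the compounds shown alone.

Among the compounds with values here, compound 1 `O=c1[nH]c(=O)n([C@H]2C[C@H](O)[C@@H](CO)O2)cc1[N+](=O)[O-]` is the only compound with a number in an ADME assay on L1210/0 cells (Mus musculus) for cytotoxicity, with a stated time of 48 h; on this read-out higher numbers stand for weaker inhibition and lower numbers for stronger inhibition; in this assay compound 1 gives 130 nM. Compound 2 `O=c1ccn([C@@H]2O[C@H](CO)[C@H](F)[C@@H]2O)c(=O)[nH]1` reaches only a limit of the assay: in this assay compound 2 gives > 200000 nM, which is the limit of > 200000 nM in this assay, at which 1 of the 2 values shown sits. Compound 3 `CC(C)(C)C#Cc1cn([C@H]2C[C@H](O)[C@@H](CO)O2)c(=O)[nH]c1=O` differs from compound 1 by 3,3-dimethylbut-1-yn-1-yl in place of nitro on an aromatic carbon. Within the data shown here, no step between two measured compounds is available to set the size of this change. A loss of potency beyond the scatter is expected, with the step from compound 1 to compound 3 estimated at a 150-fold higher number from compound 1 to compound 3 (2.19 log units; beyond the scatter). Compound 3 is therefore expected to give about 20000 nM in this assay, within a range from 3000 nM to 150000 nM.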

Compound 3, half-maximal inhibitory concentration: > 200000 nM
Compound 3 gave a limit, no number; the forecaster's own chance of this, stated with the estimate: 20%; middle value at least 10-fold (1.00 log units) from the limit.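

The group on this aromatic carbon decides the read-out: 3,3-dimethylbut-1-yn-1-yl in place of nitro gives an at least 1500-fold higher number from compound 1 to compound 3 (3.18 log units; beyond the scatter) in this assay. This is the first step shown at this position, and it is large. The read-out of compound 3 is a limit and not a number, so the full size of the step cannot be read: the limit of > 200000 nM in this assay, at which 2 of the 3 values shown sit.

On these data alone, whether the loss follows from the departure of nitro or the arrival of 3,3-dimethylbut-1-yn-1-yl remains open. An amine, a carboxylic acid or an unbranched ethynyl chain on this carbon would each be needed to separate the two.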